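The compounds below may be only part of what the source reports. "The series", "measured", "known", "first", "only" and "open" are said of these compounds alone.

Measured in an assay on isolated protein for binding affinity to Alpha-1D adrenergic receptor (Rattus norvegicus), read by radioligand binding; on this read-out lower numbers stand for stronger inhibition and higher numbers for weaker inhibition:
- compound 1 `Oc1cccc2c1CCCC2c1c[nH]cn1`: 30.9 nM
- compound 2 `CCS(=O)(=O)Nc1cc(C2CCCCC2)cc2c1CCCC2c1c[nH]cn1`: 447 nM
- compound 3 `CCS(=O)(=O)Nc1cccc2c1CCCC2c1c[nH]cn1`: 1070 nM

Compound 3 stands at the highest number of the three in this assay. Its nearest neighbour is set by a 2.4-fold higher number from compound 2 to compound 3 (0.38 log units; beyond the scatter); the furthest by a 35-fold higher number from compound 1 to compound 3 (1.54 log units; beyond the scatter).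

Compound 4 `CCS(=O)(=O)Nc1cc(F)cc2c1CCCC2c1c[nH]cn1` differs from compound 3 in one place: fluoro in place of hydrogen on an aromatic carbon. Within the data shown here, the only measured step that bears on a substituent on an aromatic carbon of this kind is a 2.4-fold higher number from compound 2 to compound 3 (0.38 log units; beyond the scatter), which is modest. Among the measured compounds shown here, no fluoro analogue has been measured, so the expected step for this assay, a 1.3-fold lower number from compound 3 to compound 4 (0.13 log units; within the scatter), is small and towards a lower number, and may not clear the scatter. For compound 4 the estimate in this assay is 800 nM, within 300 nM to 2500 nM.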

Compound 4, inhibition constant: 3630 nM
Compound 4: middle estimate off by 4.5-fold (0.66 log units), on the low side; measured number above the stated range.
By their numbers in this assay, from the lowest: compound 1; then compound 2; then compound 3; then compound 4.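

In this assay, the position para to a fused ring and meta to the (ethylsulfonyl)amino group responds even to a single fluorine: fluoro in place of hydrogen gives a 3.4-fold higher number from compound 3 to compound 4 (0.53 log units; beyond the scatter). With cyclohexyl there, the series shows an 8.1-fold higher number from compound 2 to compound 4 (0.91 log units; beyond the scatter), and compound 3 lies between the two, so a substituent here can move the number in either direction. No measurement on hand explains either step.

Still open, on these data alone, is how an amine, methoxy or carboxylic acid at this position would read. Also open, as far as these compounds go, is whether fluoro has the same effect with the hydroxy group of compound 1 in place of (ethylsulfonyl)amino.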